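This account rests on a few compounds, and the source may have more. Where it says the series, first, only, none or still open, it means among the compounds named here.

Measured so far:
Compound 1 `O=C1N/C(=C\c2ccc(Cl)cc2)C(=O)N1c1ccc(Cl)cc1`: 35600 nM in a functional assay on NCI-H292 cells (Homo sapiens) for antiproliferative activity; on this read-out higher numbers stand for weaker inhibition and lower numbers for stronger inhibition.
Compound 2 `O=C(O)c1cccc(N2C(=O)N/C(=C\c3ccc(O)cc3)C2=O)c1`: in this assay compound 2 gives only > 200000 nM, which is a limit of the assay and not a number.

Compound 2 thus stands at the limit of > 200000 nM in this assay, at which 1 of the 2 values shown sits, the weak end of what is shown. Compound 3 `O=C(NCC1CCCCC1)c1cccc(N2C(=O)N/C(=C\c3ccc(O)cc3)C2=O)c1` differs from it by (cyclohexylmethyl)amino in place of hydroxy on a carbonyl carbon. For the measured compounds named here, no measured pair covers this change, so its size is open. The expected step is an at least 6.6-fold lower number from compound 2 to compound 3 (0.82 log units; beyond the scatter), toward stronger inhibition and beyond the usual scatter, though a limit remains possible. Compound 3 is estimated at 30000 nM, within 5000 nM to 200000 nM.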

Compound 3, half-maximal inhibitory concentration: 17900 nM
Compound 3: the middle estimate sits 1.7-fold (0.22 log units) above what was measured; measured number inside the range.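

In this assay, changing carboxy to (cyclohexylmethyl)carbamoyl gives an at least 11-fold lower number from compound 2 to compound 3 (1.04 log units; beyond the scatter), so the substituent on this carbonyl carbon clearly affects the read-out. Compound 2 gives a limit of the assay and not a number, so only a lower bound on the step can be read: the limit of > 200000 nM in this assay, at which 1 of the 3 values shown sits.

The compounds shown do not separate the contribution of the amide from that of the cyclohexylmethyl group. A primary amide, a methylamide or a longer alkyl chain on the amide nitrogen would address this.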